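The compounds below may be only part of what the source reports. "The series", "measured", "known", "first", "only" and "open" are said of these compounds alone.

Of the compounds shown here, three on the shared core have been measured in an assay on cell membranes for displacement of a labelled ligand from metabotropic glutamate receptor 5 (Rattus norvegicus), tested at 1 uM; a lower number here means less inhibition, a higher number more inhibition at the concentration tested (going by the name of the read-out). Compound 1 `c1ccc(-c2csc3ncccc23)cc1` gives 0%. Compound 3 `Fc1ccc(-c2nc(-c3sc4ncccc4c3-c3ccc(Cl)cc3)no2)cc1` gives 0%, level with compound 1 at the digits shown, so the two sit together at the bottom of the three numbers. Among the compounds with values here, compound 2 `CN(Cc1ccc(F)cc1)C(=O)c1sc2ncccc2c1-c1ccc(Cl)cc1` gives 13%, the only number that lies beyond the scatter from compound 1. Within the data shown here, no pair among the three differs in just one place, so no single step has been isolated in this assay.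

Compound 4 `CC(=O)c1sc2ncccc2c1-c1ccccc1` is not yet measured. Relative to compound 1 it carries acetyl in place of hydrogen on an aromatic carbon. Nothing on record separates an acetyl entering in this way from any other change, so the expectation rests on the spread of the three numbers. Among the measured compounds shown here, the step of a number 5 percentage points higher from compound 1 to compound 4 (within the scatter) is expected to be small and upward at most, probably within the scatter, because compound 2, the one member carrying a carbonyl, gives only 13%. For compound 4 an estimated read-out of 5% is taken, with a range from 0% to 20%.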

Compound 4, a percentage reported as inhibition, at one concentration (the size of the read-out at that concentration, not a potency): 17%
Compound 4: middle estimate off by 12 percentage points, on the low side, within the range that was stated.
By their numbers in this assay, from the lowest: compounds 1 and 3 (each within the scatter of the next); then compounds 2 and 4 (each within the scatter of the next).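

In this assay the first single change can be read at this position, on an aromatic carbon next to the ring sulfur and next to the ring atom that bears a phenyl group: acetyl in place of hydrogen gives a number 17 percentage points higher from compound 1 to compound 4 (beyond the scatter) and the step is modest. This place on the shared core therefore accepts a small substituent with a read-out that lifts off the floor, although the number remains inhibition at one concentration and not a potency. Nothing on record explains the step.

Open, on these data alone, is whether the carbonyl or the whole acetyl carries the step, which a hydroxymethyl group, a propanoyl chain or a carboxylic acid in the same place could test. Also open, as far as these compounds go, is how the acetyl step behaves with a chlorine on the phenyl group.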